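Series notes: open-chain amine replacing aminocyclopropyl

This account rests on a few compounds, and the source may have more. Where it says the series, first, only, none or still open, it means among the compounds named here.

Compound 2 `C[C@@H]1SCc2ncnc(N3CCN(C(=O)C(Cc4ccc(Cl)c(F)c4)CC4(N)CC4)CC3)c21` gives 3 nM in an assay on isolated protein for inhibition of RAC-alpha serine/threonine-protein kinase (Homo sapiens) (on this read-out lower numbers stand for stronger inhibition and higher numbers for weaker inhibition), and sits alongside compound 1 `CC(C)NCC(Cc1ccc(Cl)c(F)c1)C(=O)N1CCN(c2ncnc3c2[C@H](C)SC3)CC1`, which in this assay gives 2 nM, the two within the scatter of each other. Among the compounds with values here, the only measured step at this part of the molecule, a 1.5-fold higher number from compound 1 to compound 2 (0.18 log units; within the scatter), did not move the number beyond the scatter. Compound 3 `C[C@@H]1SCc2ncnc(N3CCN(C(=O)C(Cc4ccc(Cl)c(F)c4)CC(C)(C)N)CC3)c21` carries the change (1-amino-1-methylethyl in place of 1-aminocyclopropyl on a saturated chain carbon, two bonds along the chain from a carbonyl carbon), again at that same place. On this one precedent the expected step in this assay is a 1.3-fold higher number from compound 2 to compound 3 (0.12 log units; within the scatter), with no direction claimed beyond the scatter. Compound 3 is therefore estimated at 4 nM, within a range of 1.5 nM to 12 nM.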

Compound 3, half-maximal inhibitory concentration: 7 nM
For compound 3 the middle estimate is 1.8-fold (0.24 log units) below the measured one; the measured number falls inside the stated range.
By their numbers in this assay, from the lowest: compounds 1 and 2 (each within the scatter of the next); then compound 3.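

In this assay, 1-amino-1-methylethyl in place of 1-aminocyclopropyl gives a 2.3-fold higher number from compound 2 to compound 3 (0.37 log units; beyond the scatter), so this place on the saturated chain carbon does register a change, although a modest one. Against the isopropylamino group the change gives a 3.5-fold higher number from compound 1 to compound 3 (0.54 log units; beyond the scatter), whereas the step from isopropylamino to 1-aminocyclopropyl stayed within the scatter. Nothing available explains this difference between the open-chain and ring groups. Open, from the compounds shown here alone, is whether a larger ring, such as 1-aminocyclobutyl, would track compound 2 or compound 3. Going by these compounds, a longer chain, such as 3-amino-3-methylbutyl, also remains open at this place.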